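Chloro in place of hydrogen, starting from a limit

The source may report more compounds than this note shows. Statements on the series, on what has been measured and on what is new or still open speak of the compounds shown alone.

Three measured compounds share one core and differ only in the group on the amide-type nitrogen. Compound 3 `O=C(COc1ccc(/C=C2\SC(=O)NC2=O)cc1)Nc1ccccc1` carries a plain phenyl; in a functional assay on KB cells (Homo sapiens) for inhibition (a higher number here means a weaker inhibitor of growth, a lower number a stronger inhibitor of growth), compound 3 gives > 100000 nM, which is a limit of the assay rather than a number. Compound 1 `O=C(COc1ccc(/C=C2\SC(=O)NC2=O)cc1)Nc1cccc([N+](=O)[O-])c1` gives > 100000 nM, also a limit. Compound 2 `O=C(COc1ccc(/C=C2\SC(=O)NC2=O)cc1)Nc1ccc(F)cc1` gives > 100000 nM, again a limit. Because every value sits at the limit of > 100000 nM in this assay, at which 3 of the 3 values shown sit, the steps a step that the two limits leave unreadable from compound 1 to compound 2, a step that the two limits leave unreadable from compound 1 to compound 3 and a step that the two limits leave unreadable from compound 2 to compound 3 cannot be sized. Compound 4 `O=C(COc1ccc(/C=C2\SC(=O)NC2=O)cc1)Nc1ccc(Cl)cc1` differs from compound 3 by chloro in place of hydrogen on an aromatic carbon. The step that the two limits leave unreadable from compound 2 to compound 3 gave no readable size, so for compound 4 a limit is expected again, with the step that the limit leaves unreadable from compound 3 to compound 4 estimated as nothing beyond the scatter. Compound 4 is therefore expected near 200000 nM, within 50000 nM to 1000000 nM.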

Compound 4, concentration for 50% growth inhibition: 50300 nM
Estimate against measurement, compound 4: 4.0-fold (0.60 log units) above, within the range that was stated.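

In this assay, compound 4, with its 4-chlorophenyl, is the only compound shown that gives a number rather than a limit. Chloro in place of hydrogen gives an at least 1.9-fold lower number from compound 3 to compound 4 (0.29 log units; that floor lies within the scatter), chloro in place of fluoro gives an at least 1.9-fold lower number from compound 2 to compound 4 (0.29 log units; that floor lies within the scatter), and the change of the whole aryl group gives an at least 1.9-fold lower number from compound 1 to compound 4 (0.29 log units; that floor lies within the scatter). These are only floors, and the true sizes stay unknown, since the other compounds sit at a limit: the limit of > 100000 nM in this assay, at which 3 of the 4 values shown sit.

As far as these compounds go, whether bromo, methyl or a carboxylic acid in place of the chloro would give a number or a limit again stays open.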